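Cytotoxicity notes: aryl substitution on the ring nitrogen

The source may hold more compounds than are shown below. What is called first, only, known or untested is meant among the compounds shown, and "the series" means these compounds.

Measured so far:
compound 1, `Nc1c(C(=O)c2ccccc2)sc(Nc2ccccc2)c1-c1nnc(NC(=O)c2ccccc2)o1`: 101 ug/mL
compound 2, `Nc1n[nH]c(Nc2ccccc2)c1-c1nnc(NC(=O)c2ccccc2)o1`: 36.3 ug/mL

In an ADME assay on Vero cells (Chlorocebus sabaeus) for cytotoxicity, read by MTT assay, with a stated time of 96 h (on this read-out higher numbers stand for weaker inhibition and lower numbers for stronger inhibition), compound 1 gives 101 ug/mL. In this assay compound 2 gives 36.3 ug/mL, the lower of the two numbers; the gap to compound 1 is beyond the scatter, so compound 2 is the stronger of the pair on this read-out. The two compounds differ in more than one place, so no single change can be tied to that gap.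

Compound 3, `Nc1nn(-c2ccccc2)c(Nc2ccccc2)c1-c1nnc(NC(=O)c2ccccc2)o1`, is not yet measured. Within the data shown here, it differs from compound 2 by phenyl in place of hydrogen on an aromatic nitrogen, and no measured pair reproduces this change, so there is no step to lean on. The expectation for the step from compound 2 to compound 3 in this assay is a 1.2-fold lower number from compound 2 to compound 3 (0.08 log units; within the scatter), a change not clearly beyond the scatter in either direction. Compound 3 is estimated at 30 ug/mL, with a range from 12 ug/mL to 90 ug/mL.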

Compound 3, half-maximal inhibitory concentration: 98.8 ug/mL
Beside the measured number, compound 3's estimate is 3.3-fold (0.52 log units) below it; measured number outside the range, above it.
By their numbers in this assay, from the lowest: compound 2; then compounds 3 and 1 (each within the scatter of the next).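

In this assay this ring nitrogen now has its first measured step: the change a 2.7-fold higher number from compound 2 to compound 3 (0.43 log units; beyond the scatter) is phenyl in place of hydrogen on an aromatic nitrogen, and it moves toward weaker inhibition. The position, next to the ring atom that bears an anilino group, therefore responds to this change on this read-out, although the step is only modest. Nothing measured here accounts for the step.

The compounds shown hold only hydrogen and phenyl on this nitrogen, so one step cannot separate an effect of phenyl itself from what any other group there would do. Going by these compounds, whether methyl, benzyl or 4-chlorophenyl on the same nitrogen would move the number in the same direction, or by a similar amount, remains open.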